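From Methyl to Nitro: One Aromatic Substitution Examined

The source may report more compounds than this note shows. Statements on the series, on what has been measured and on what is new or still open speak of the compounds shown alone.

Of the compounds shown here, two have been measured in a functional assay on A549 cells (Homo sapiens) for antiproliferative activity, read by MTT assay, with a stated time of 48 h; on this read-out higher numbers stand for weaker inhibition and lower numbers for stronger inhibition. Compound 1 `O=C(/C=C/c1ccc([N+](=O)[O-])cc1)Nc1ccc2ncnc(Nc3cccc(Br)c3)c2c1` gives 1.85 ug/mL. Compound 2 `Cc1ccc(/C=C/C(=O)Nc2ccc3ncnc(Nc4cccc(Cl)c4)c3c2)cc1` gives 6.03 ug/mL, the higher of the two numbers, and its gap to compound 1 lies beyond the usual scatter. Compound 3 `O=C(/C=C/c1ccc([N+](=O)[O-])cc1)Nc1ccc2ncnc(Nc3cccc(Cl)c3)c2c1` differs from compound 2 by nitro in place of methyl on an aromatic carbon. Going by the values given here, no measured pair traces this exact change. One expects the number to move downward toward stronger inhibition by a step of a 2.4-fold lower number from compound 2 to compound 3 (0.38 log units; beyond the scatter) that likely exceeds the scatter, because compound 1 with the same nitro group gives 1.85 ug/mL. Compound 3 is estimated at 2.5 ug/mL, within 1 ug/mL to 6 ug/mL.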

Compound 3, half-maximal inhibitory concentration: 5.26 ug/mL
Compound 3: middle estimate off by 2.1-fold (0.32 log units), on the low side, and the stated range covers the measured number.
By their numbers in this assay, from the lowest: compound 1; then compounds 3 and 2 (each within the scatter of the next).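

In this assay, nitro in place of methyl on an aromatic carbon, para to a large group, gives a 1.1-fold lower number from compound 2 to compound 3 (0.06 log units; within the scatter) and so does not separate these two chloro compounds. Chloro in place of bromo gives a 2.8-fold higher number from compound 1 to compound 3 (0.45 log units; beyond the scatter) and shows that the lower number of compound 1 goes with the bromo group and not with nitro alone. Nothing shown gives a cause for either result. On these data alone, it remains open whether an amine or a carboxylic acid in place of nitro would shift the number, and whether methyl and nitro would also match alongside bromo.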